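A few compounds are considered here, and "the series" means these few. Any claim that something is new, unique, unknown or untested is made for them only; others in the source may bear on it.

Of the compounds shown here, three that share one core have been tested in a functional assay on the whole organism (strain Swiss albino) with Mus musculus as the target, in the maximal electroshock model, with a stated time of 4 h; a higher number here means that more compound is needed for the effect, a lower number that less compound is needed. Compound 1 `Cc1ccc(/C=N\NC(=O)Nc2nnc(COc3ccc4ccccc4c3)o2)cc1` needs 300 mg/kg in this assay. Compound 2 `O=C(NN=C(c1ccccc1)c1ccccc1)Nc1nnc(COc2ccc3ccccc3c2)o1` needs 300 mg/kg in this assay. Compound 3 `O=C(N/N=C(/c1ccccc1)c1ccc(O)cc1)Nc1nnc(COc2ccc3ccccc3c2)o1` needs 300 mg/kg in this assay, which places compound 3 level with compound 1 and compound 2 at the digits shown. For the measured compounds named here, the one single-point step measured so far, no change at the digits printed from compound 2 to compound 3 (within the scatter), put a hydroxy group onto an aromatic carbon and moved the dose not at all within the scatter.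

Compound 4 `COc1ccc(/C(=N\NC(=O)Nc2nnc(COc3ccc4ccccc4c3)o2)c2ccccc2)cc1` differs from compound 3 by methyl in place of hydrogen on an oxygen on an aromatic ring. Going by the values given here, no measured step covers this exact change, but it sits at the same place as the step of no change at the digits printed from compound 2 to compound 3 (within the scatter), which left the dose unchanged, and all three measured doses lie at one level. The expectation is therefore a step of no size beyond the scatter. Compound 4 is estimated to need 300 mg/kg, within a range from 150 mg/kg to 600 mg/kg. This estimate corresponds to an expected step of no change at the digits printed from compound 3 to compound 4 (within the scatter).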

Compound 4, minimum effective dose: 300 mg/kg
Compound 4: middle estimate and measured number agree at the digits printed; the range from low to high includes it.
By their numbers in this assay, from the lowest: compounds 1, 2, 3 and 4 (each within the scatter of the next).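

In this assay the hydroxy to methoxy change gives no change at the digits printed from compound 3 to compound 4 (within the scatter) and so shows that the oxygen on the aromatic ring can carry a methyl as well as a hydrogen with no visible effect on the dose. Compared with the plain hydrogen on the aromatic carbon, the methoxy group gives no change at the digits printed from compound 2 to compound 4 (within the scatter) as well, so hydrogen, hydroxy and methoxy read alike at this place in compound 2, compound 3 and compound 4. No measured evidence is available to explain this flat result.

Going by these compounds, whether a longer chain such as butoxy on this oxygen, or an amine or a carboxylic acid in place of the hydroxy, would move the dose remains open. On these data alone, since all four compounds read the same, it is also open which part of the structure, if any, the dose responds to.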